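Adding a Second Chlorine: What to Expect for Compound 4

The compounds below may be only part of what the source reports. "The series", "measured", "known", "first", "only" and "open" are said of these compounds alone.

Measured compounds:
compound 1 `O=C(Nc1ccccc1)C(Cl)Cl` — "not determined" (no result reported) in a functional assay on KB cells (Homo sapiens) for antiproliferative activity, read by MTT assay, with a stated time of 72 h; a lower number here means a stronger inhibitor, a higher number a weaker inhibitor
compound 2 `O=C(Nc1cccc(Cl)c1)C(Cl)Cl` — "not determined" (no result reported) in this assay
compound 3 `O=C(Nc1ccc(Cl)cc1)C(Cl)Cl` — 60800 nM in this assay

For the measured compounds named here, compound 3 stands alone: it carries the only number in this assay, while compound 1 and compound 2 have none, so no step between measured compounds can be drawn and the series gives no direction of its own. Compound 4 `O=C(Nc1ccc(Cl)c(Cl)c1)C(Cl)Cl` differs from compound 3 by a single change, (chloro in place of hydrogen on an aromatic carbon). Going by the values given here, with no measured step to lean on, a small shift is expected, one that may not exceed the usual scatter, with a slight lean towards stronger inhibition. The expected step is a 1.5-fold lower number from compound 3 to compound 4 (0.18 log units; within the scatter). Compound 4 is therefore estimated at 40000 nM, within a range from 15000 nM to 120000 nM.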

Compound 4, half-maximal inhibitory concentration: 7050 nM
For compound 4 the middle estimate is 5.7-fold (0.75 log units) above the measured one; the measured number lies below the stated range.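

In this assay, the series now has its first readable step, an 8.6-fold lower number from compound 3 to compound 4 (0.94 log units; beyond the scatter). It shows that this position, ortho to a chloro group and meta to a group of 6 heavy atoms, is one where a single added chloro can clearly strengthen inhibition. Nothing available here explains why the number falls. On these data alone, whether a bromine atom, a methyl group or an amine at this same position would move the number in the same way remains open. So does whether a third chloro elsewhere on the ring would lower it further.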